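Removing the methyls and the oxygen from the amine on the core

The source may report more compounds than this note shows. Statements on the series, on what has been measured and on what is new or still open speak of the compounds shown alone.

Compound 1 `COCC(=O)N1C[C@@H](C)N(c2ncc3[nH]nc(-c4ccc(N5CCN[C@H](C)C5)nc4)c3n2)[C@@H](C)C1` gives 7.3 nM in an assay on Sf9 cells for inhibition of activin receptor type-1 (Homo sapiens), read by HTRF, with a stated time of 3 h, in the presence of a further agent that is not named here; a lower number here means a stronger inhibitor, a higher number a weaker inhibitor.
Compound 2 `C[C@@H]1CN(c2ccc(-c3n[nH]c4cnc(N5[C@H](C)CCC[C@@H]5C)nc34)cn2)CCN1` gives 2.5 nM in this assay.
Compound 3 `C[C@@H]1CN(c2ccc(-c3n[nH]c4cnc(N5[C@H](C)COC[C@@H]5C)nc34)cn2)CCN1` gives 23 nM in this assay.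

Compound 3 has the highest number of the three in this assay, and thus the weakest inhibition among them; compound 1 sits nearest to it and compound 2 furthest away. Compound 4 `C[C@@H]1CN(c2ccc(-c3n[nH]c4cnc(N5CCCCC5)nc34)cn2)CCN1` is not yet measured. It differs from compound 3 in one place: piperidin-1-yl in place of 3,5-dimethylmorpholin-4-yl on an aromatic carbon. Among the measured compounds shown here, only one measured step touches this position: a 9.2-fold higher number from compound 2 to compound 3 (0.96 log units; beyond the scatter). That step exchanged one dimethylated six-membered ring for another, so it speaks to the ring heteroatom but not to the two methyl groups, which compound 4 also drops. Nothing in the data tells what losing both methyls and the oxygen does together. The expectation for compound 4 is therefore a modest move back toward the number of compound 2, a 2.9-fold lower number from compound 3 to compound 4 (0.46 log units; beyond the scatter), with a wide range. Compound 4 is estimated at 8 nM, between 2 nM and 30 nM.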

Compound 4, half-maximal inhibitory concentration: 40 nM
For compound 4 the middle estimate is 5.0-fold (0.70 log units) below the measured one, and the stated range ends below it.
By their numbers in this assay, from the lowest: compound 2; then compound 1; then compounds 3 and 4 (each within the scatter of the next).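

Taking both methyl groups off the 2,6-dimethylpiperidin-1-yl group carries a real cost in this assay: the change gives a 16-fold higher number from compound 2 to compound 4 (1.20 log units; beyond the scatter) and shows that the low number of compound 2 depends on those two methyl groups, not on the piperidine ring alone. Piperidin-1-yl and 3,5-dimethylmorpholin-4-yl, by contrast, cannot be told apart, with a 1.7-fold higher number from compound 3 to compound 4 (0.24 log units; within the scatter) as the step between them, so among compound 2, compound 3 and compound 4 only the 2,6-dimethylpiperidin-1-yl group stands apart. Nothing at hand explains how these groups produce this pattern.

The compounds shown leave open whether one methyl group, as in 2-methylpiperidin-1-yl, would be enough to recover the low number of compound 2. They also leave open how morpholin-4-yl without methyl groups would compare with piperidin-1-yl.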